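Removing the benzyloxycarbonyl group from compound 1

The source may hold more compounds than are shown below. What is called first, only, known or untested is meant among the compounds shown, and "the series" means these compounds.

Measured in a functional assay on CCRF-CEM cells (Homo sapiens) for inhibition, with a stated time of 72 h (on this read-out lower numbers stand for stronger inhibition and higher numbers for weaker inhibition), so far:
compound 1 `CCC(C)N(C(=O)[C@H](CC(=O)OC)NC(=O)OCc1ccccc1)C1(C(=O)NCc2ccccc2)CCN(Cc2ccccc2)CC1` gives 4500 nM
compound 2 `CCC(C)N(C(=O)[C@@H](NC(=O)OCc1ccccc1)[C@@H](C)CC)C1(C(=O)NCc2ccccc2)CCN(Cc2ccccc2)CC1` gives 111000 nM
compound 3 `COC(=O)C[C@H](NC(=O)OCc1ccccc1)C(=O)N(C1CC1)C1(C(=O)NCc2ccccc2)CCN(Cc2ccccc2)CC1` gives 6200 nM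

Compound 1 sits at the low end of these numbers, and only compound 2 clearly departs from it. The next compound, compound 4 `CCC(C)N(C(=O)[C@@H](N)CC(=O)OC)C1(C(=O)NCc2ccccc2)CCN(Cc2ccccc2)CC1`, differs from compound 1 as follows: hydrogen in place of benzyloxycarbonyl on an amine nitrogen. In short, hydrogen stands in place of benzyloxycarbonyl on an amine nitrogen.

Among the measured compounds shown here, all three measured compounds carry that group, so no measured step tests its loss. Two steps offer only indirect guidance. A change on the amide-type nitrogen gave a 1.4-fold higher number from compound 1 to compound 3 (0.14 log units; within the scatter), which is within the scatter. A change on a saturated chain carbon gave a 25-fold higher number from compound 1 to compound 2 (1.39 log units; beyond the scatter), which is well beyond it. Compound 2 at 111000 nM shows that a single change can move the number far, so a sizeable rise, meaning weaker inhibition, is expected in this assay, though this direction remains a judgement. The expected change is a 6.7-fold higher number from compound 1 to compound 4 (0.82 log units; beyond the scatter) overall. For compound 4 the estimate is 30000 nM, within an expected range of 8000 nM to 120000 nM overall.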

Compound 4, half-maximal inhibitory concentration: 238000 nM
Beside the measured number, compound 4's estimate is 7.9-fold (0.90 log units) below it, outside the stated range (above it).
By their numbers in this assay, from the lowest: compounds 1 and 3 (each within the scatter of the next); then compound 2; then compound 4.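

In this assay, among the compounds shown here, the benzyloxycarbonyl group on this amine nitrogen proves to matter a great deal: hydrogen in its place gives a 53-fold higher number from compound 1 to compound 4 (1.72 log units; beyond the scatter), and this is the first direct test of the position, since compounds 1, 2 and 3 all carry the group. The change removes 10 heavy atoms, including one six-membered aromatic ring of carbon only, and its effect is as clearly beyond the scatter as that of the sec-butyl change, a 25-fold higher number from compound 1 to compound 2 (1.39 log units; beyond the scatter). Nothing available explains why the number rises so far.

The compounds shown leave open which part of the benzyloxycarbonyl group counts. An acetyl group on this nitrogen would keep a carbonyl without the aromatic ring, while a benzyl group would keep the ring without the carbonyl.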